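Swapping the oxetane for an acetylated azetidine on the core

The source may report more compounds than this note shows. Statements on the series, on what has been measured and on what is new or still open speak of the compounds shown alone.

Two compounds share a core in which a methoxy group and a dichlorinated benzenesulfonamide sit on a fused bicyclic system. Compound 1 `COc1cc2[nH]c(=O)[nH]c2cc1NS(=O)(=O)c1cccc(Cl)c1Cl` carries a hydrogen on the ring nitrogen of that system. In an assay on cells (blood) for antagonist activity at C-C chemokine receptor type 4 (Homo sapiens), read by flow cytometry (on this read-out higher numbers stand for weaker binding and lower numbers for tighter binding), compound 1 gives 5010 nM. Compound 2 `COc1cc2c(cc1NS(=O)(=O)c1cccc(Cl)c1Cl)[nH]c(=O)n2C1COC1` carries oxetan-3-yl on that same nitrogen instead. In this assay compound 2 returns only a limit, > 10000 nM. Compound 2 thus stands at the limit of > 10000 nM in this assay, at which 1 of the 2 values shown sits, so its true number is not known, only that it is no tighter than this boundary. For the measured compounds named here, the one measured step, an at least 1.9-fold higher number from compound 1 to compound 2 (0.30 log units; that floor lies within the scatter), is therefore a floor and not a full measurement. Compound 3 `COc1cc2c(cc1NS(=O)(=O)c1cccc(Cl)c1Cl)[nH]c(=O)n2C1CN(C(C)=O)C1` differs from compound 2 by 1-acetylazetidin-3-yl in place of oxetan-3-yl on an aromatic nitrogen. Going by the values given here, the only step that bears on this change is the one from hydrogen to oxetan-3-yl, and it points toward weaker binding, although only its floor is known. Compound 3 is therefore expected to stay weak, with a step that the limit leaves unreadable from compound 2 to compound 3 estimated from compound 2. For compound 3 the estimated value is 15000 nM, expected to fall between 5000 nM and 50000 nM, most likely again reported as a limit.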

Compound 3, dissociation constant: > 10000 nM
Compound 3: a limit, no number (the forecaster's own chance of this, stated with the estimate: 75%); the middle value does not contradict the limit.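

Compound 3 shows that a second group on this aromatic nitrogen, 1-acetylazetidin-3-yl, also gives no number in this assay, only a limit. Measured against the hydrogen of compound 1, this change gives an at least 1.9-fold higher number from compound 1 to compound 3 (0.30 log units; that floor lies within the scatter), which is a floor and not a full measurement. The step between compound 2 and compound 3 cannot be read, so the two groups cannot be ranked against each other, and the position has now taken two different four-membered rings with neither giving a number: the limit of > 10000 nM in this assay, at which 2 of the 3 values shown sit.

As far as these compounds go, how far the true values of compound 2 and compound 3 lie beyond the limit remains open, and so does whether either group truly binds more weakly than hydrogen. Also open, from the compounds shown here alone, is whether a plain methyl group or an azetidine with a free amine in place of the acetylated nitrogen would give a measurable number at this position.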